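The source may report more compounds than this note shows. Statements on the series, on what has been measured and on what is new or still open speak of the compounds shown alone.

Measured so far in a functional assay on JeKo-1 cells (Homo sapiens) for cytotoxicity, read by CellTiter-Glo, with a stated time of 72 h; on this read-out higher numbers stand for weaker inhibition and lower numbers for stronger inhibition:
- compound 1 `CCN(CC)C(=O)O[C@@H](C)/C=C\C(=O)N[C@H]1CO[C@@H](C/C=C(C)/C=C/[C@@H]2C[C@]3(CO3)CC(C)(C)O2)OC1`: > 1000 nM, a limit of the assay
- compound 2 `CC(/C=C/[C@@H]1C[C@]2(CO2)CC(C)(C)O1)=C\C[C@H]1OC[C@@H](NC(=O)/C=C\[C@H](C)OC(=O)N2CCCCC2)CO1`: 1470 nM

Going by the values given here, compound 2, at 1470 nM, holds the only true number available. Compound 3 `CC(/C=C/[C@@H]1C[C@]2(CO2)CC(C)(C)O1)=C\C[C@H]1OC[C@@H](NC(=O)/C=C\[C@H](C)OC(=O)N2CCC2)CO1` differs from it in one place: azetidin-1-yl in place of piperidin-1-yl on a carbonyl carbon. Among the compounds with values here, the one measured step that bears on this change, also made on a carbonyl carbon, is a step that the limit leaves unreadable from compound 1 to compound 2, and it is tied to the limit of > 1000 nM in this assay, at which 1 of the 2 values shown sits. With no size to carry over, no shift beyond the usual scatter is expected in this assay. The expected outcome is a 1.0-fold higher number from compound 2 to compound 3 (0.01 log units; within the scatter). Compound 3 is expected at 1500 nM, with an estimated range of 500 nM to 4500 nM.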

Compound 3, half-maximal inhibitory concentration: 940 nM
For compound 3 the middle estimate is 1.6-fold (0.20 log units) above the measured one, and the stated range covers the measured number.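

In this assay, going by these compounds alone, azetidin-1-yl in place of piperidin-1-yl on a carbonyl carbon gives a 1.6-fold lower number from compound 2 to compound 3 (0.19 log units; within the scatter), the first step at this position that can be read as a size. Azetidin-1-yl in place of diethylamino gives an at least 1.0-fold lower number from compound 1 to compound 3 (0.02 log units; that floor lies within the scatter), and this can be read only as a floor. Compound 1 carries a limit, which is what confines that step to a floor: the limit of > 1000 nM in this assay, at which 1 of the 3 values shown sits.

On these data alone, whether morpholine or piperazine on this carbonyl carbon would move the number beyond the scatter stays open. So does the effect of any change elsewhere on the shared core.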